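Dropping the Fluoro from Compound 2

A few compounds are considered here, and "the series" means these few. Any claim that something is new, unique, unknown or untested is made for them only; others in the source may bear on it.

Compound 1, `COc1ccc2nc(-c3ccc(C)c(N)c3)sc2c1`: in a functional assay on A549 cells (Homo sapiens) for cytotoxicity, read by MTT assay, with a stated time of 2 days (on this read-out lower numbers stand for stronger inhibition and higher numbers for weaker inhibition), compound 1 gives > 50000 nM, which is a limit of the assay rather than a number.
Compound 2, `Cc1ccc(-c2nc3ccc(F)cc3s2)cc1N`: in this assay compound 2 gives > 50000 nM, likewise a limit.

Compound 2 therefore stands at the limit of this assay, and the other measured value sits at the same limit (the limit of > 50000 nM in this assay, at which 2 of the 2 values shown sit). Among the compounds with values here, the one measured step, from compound 1 to compound 2, is a step that the two limits leave unreadable from compound 1 to compound 2, a change of fluoro in place of methoxy on an aromatic carbon whose size the two limits leave unreadable.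

Compound 3, `Cc1ccc(-c2nc3ccccc3s2)cc1N`, differs from compound 2 by hydrogen in place of fluoro on an aromatic carbon. Within the data shown here, no measured step bears directly on this change, and the single step that was measured gives no size at all. Among the measured compounds shown here, the data thus offer no direction for the step to compound 3, neither stronger nor weaker inhibition beyond the scatter. Because compound 2 gives > 50000 nM, compound 3 is expected to remain at the limit as well, with an estimate of 80000 nM and a range from 20000 nM to 300000 nM. The expected step from compound 2 to compound 3 is a step that the limit leaves unreadable from compound 2 to compound 3.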

Compound 3, half-maximal inhibitory concentration: > 50000 nM
Compound 3 was reported as a limit; the forecaster's own chance of this, stated with the estimate: 85%; the middle value is on the limit's open side.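

No step can be read among compound 1, compound 2 and compound 3, since the values of all three are limits and not numbers in this assay: the limit of > 50000 nM in this assay, at which 3 of the 3 values shown sit.

The compounds shown leave open whether methoxy, fluoro or hydrogen on this aromatic carbon makes any difference to inhibition, and how far each compound lies beyond the limit.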